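Capping the Phenol Oxygen: From Compound 3 to Compound 4

A few compounds are considered here, and "the series" means these few. Any claim that something is new, unique, unknown or untested is made for them only; others in the source may bear on it.

Compound 1, `Cc1ccc2c3c(n(C)c(=O)c2c1)-c1ccccc1OCC3`, gives 8760 nM in a functional assay on HeLa cells (Homo sapiens) for cytotoxicity, read by sulforhodamine B assay; a lower number here means a stronger inhibitor, a higher number a weaker inhibitor. Compound 2, `COc1ccc(Cn2c(-c3ccccc3O)c(Br)c3ccccc3c2=O)cc1`, gives 36800 nM in this assay. Compound 3, `COc1ccc(Cn2c(-c3ccccc3O)c(Br)c3cc(C)ccc3c2=O)cc1`, gives 20400 nM in this assay.

Among these three numbers compound 3 sits close to compound 2, the two lying within the scatter of each other, while its number is lower than that of compound 1 by a margin beyond the scatter. For the measured compounds named here, the only step measured in one place is a 1.8-fold lower number from compound 2 to compound 3 (0.26 log units; within the scatter), which concerns a methyl on an aromatic carbon and leaves the number essentially unchanged.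

Compound 4, `C=COc1ccccc1-c1c(Br)c2cc(C)ccc2c(=O)n1Cc1ccc(OC)cc1`, differs from compound 3 in one place: vinyl in place of hydrogen on an oxygen on an aromatic ring. Going by the values given here, no measured step touches this oxygen, so nothing in the data speaks for a shift in either direction, and the step is expected to stay within the scatter, a 1.0-fold lower number from compound 3 to compound 4 (0.01 log units; within the scatter). Compound 4 is therefore estimated at 20000 nM in this assay, with a range from 7000 nM to 60000 nM.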

Compound 4, half-maximal inhibitory concentration: 14800 nM
Estimate against measurement, compound 4: 1.4-fold (0.13 log units) above; measured number inside the range.
By their numbers in this assay, from the lowest: compounds 1, 4, 3 and 2 (each within the scatter of the next, the first and the last beyond it).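

In this assay, for the compounds shown here, the step from hydroxy to vinyloxy is a 1.4-fold lower number from compound 3 to compound 4 (0.14 log units; within the scatter) and is the first measured change at this oxygen on the aromatic ring. Compounds 2 and 3 both carry the hydroxy group, so they could say nothing about this position; compound 4 shows that the hydrogen on this oxygen can be replaced by vinyl while the number stays within the scatter of that of compound 3. No supporting measurement bears on this result, so the data offer no explanation for it.

The compounds shown give only vinyl as a replacement at this oxygen, so it remains open whether the number would also hold with a methyl, a benzyl or a longer chain ending in an amine. From the compounds shown here alone, whether any group here could move the number beyond the scatter, in either direction, also remains open.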